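Bromo Replacing Trifluoromethyl on the Aryl Ring

A few compounds are considered here, and "the series" means these few. Any claim that something is new, unique, unknown or untested is made for them only; others in the source may bear on it.

Among the measured compounds shown here, compound 3 `C#CCNC1CCc2c(SCCc3ccc(C(F)(F)F)cc3)cccc21` is the only member of this small set with a numerical result: in an ADME assay on isolated protein for inhibition of Amine oxidase [flavin-containing] B (Homo sapiens) (a higher number here means a weaker inhibitor, a lower number a stronger inhibitor), compound 3 gives 8780 nM. Compound 1 `C#CCNC1CCc2c(SCc3cccc(C)c3)cccc21` gives > 100000 nM, which is the limit of > 100000 nM in this assay, at which 1 of the 3 values shown sits, a limit of the assay rather than a number. Compound 2 `C#CCNC1CCc2c(SCCc3cccc(Cl)c3)cccc21` gives "not determined" (no result reported) in this assay, that is, no result at all. Compound 4 `C#CCNC1CCc2c(SCCc3ccc(Br)cc3)cccc21` differs from compound 3 by a single change: bromo in place of trifluoromethyl on an aromatic carbon. For the measured compounds named here, no measured pair here shows what such a change does, so only a modest shift, toward a slightly stronger inhibitor, is expected. The expected step from compound 3 to compound 4 is a 1.5-fold lower number from compound 3 to compound 4 (0.17 log units; within the scatter). Compound 4 is therefore estimated at 6000 nM, with a likely range from 1500 nM to 25000 nM.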

Compound 4, half-maximal inhibitory concentration: 1250 nM
Compound 4: middle estimate off by 4.8-fold (0.68 log units), on the high side, and the stated range ends above it.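

At this place, on an aromatic carbon para to a large group, bromo in place of trifluoromethyl gives a 7.0-fold lower number from compound 3 to compound 4 (0.85 log units; beyond the scatter) in this assay. Among the compounds shown here, this is the first measured pair in the set, and it shows that changing this one group is enough to move the number beyond the usual scatter. Nothing measured here explains why the number falls. From the compounds shown here alone, whether a nitrile, a methoxy or an amine on that same carbon would give a lower or a higher number remains open.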